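A few compounds are considered here, and "the series" means these few. Any claim that something is new, unique, unknown or untested is made for them only; others in the source may bear on it.

Measured compounds, with half-life in an ADME assay for metabolic stability, read by HPLC, at pH 7.4; on this read-out lower numbers stand for a shorter-lived compound and higher numbers for a longer-lived compound:

compound 1, `CCCCCCCCCNC(=O)Oc1ccc(Cl)cc1C(=O)Nc1ccc(Cl)cc1`: 43 h
compound 2, `CCCCCCCCCCNC(=O)Oc1ccc(Cl)cc1C(=O)Nc1ccc(Cl)cc1`: 43 h
compound 3, `CCCCCCNC(=O)Oc1ccc(Cl)cc1C(=O)Nc1ccc(Cl)c(Cl)c1`: 43 h

Compound 1 and compound 2 share a core and differ by methyl in place of hydrogen on a saturated chain carbon, nine bonds along the chain from an amide-type nitrogen. On that change the measured step is no change at the digits printed from compound 1 to compound 2 (within the scatter). Compound 3 stands level with compound 1 and compound 2; the difference between the core of compound 3 and the core of compound 1 is not broken down here.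

Compound 4, `CCCCCCCNC(=O)Oc1ccc(Cl)cc1C(=O)Nc1ccc(Cl)c(Cl)c1`, is not yet measured. It differs from compound 3 by methyl in place of hydrogen on a saturated chain carbon, six bonds along the chain from an amide-type nitrogen. This is the same kind of change as from compound 1 to compound 2, but the place is not the same: here the carbon lies six bonds along the chain from an amide-type nitrogen, there nine bonds. For compound 4 the expected step is no change at the digits printed from compound 3 to compound 4 (within the scatter), resting on the flat step no change at the digits printed from compound 1 to compound 2 (within the scatter) measured on the first core. Compound 4 is thus estimated at 43 h, expected between 22 h and 86 h.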

Compound 4, half-life: 43 h
For compound 4 middle estimate and measured number coincide at the digits printed; the range from low to high includes it.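

In this assay, the added methyl gives no change at the digits printed from compound 3 to compound 4 (within the scatter). Set beside the earlier step, the change reads the same on the two cores: the same change on two cores in this assay, no change at the digits printed (within the scatter) from compound 1 to compound 2 and no change at the digits printed (within the scatter) from compound 3 to compound 4, 1.0-fold (0.00 log units) apart, within the scatter of two such steps. This shows the flat step carried over for these two pairs only, with the carbon at different places on the chain, and it does not show that the same would hold on another core or that the half-life responds to chain length at all, since every compound shown prints the same value.

Left open is whether a shorter chain such as butyl, a branched chain, or a chain carrying an amine or a carboxylic acid would shift the half-life in this assay.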